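A few compounds are considered here, and "the series" means these few. Any claim that something is new, unique, unknown or untested is made for them only; others in the source may bear on it.

Among the compounds with values here, in a functional assay on COLO 205 cells (Homo sapiens) for inhibition, read by sulforhodamine B assay (on this read-out higher numbers stand for weaker inhibition of growth and lower numbers for stronger inhibition of growth), compound 3 `Oc1cccc2[nH]c(-c3ccc(-c4ccc(-c5ccccc5)cc4)cc3)nc12` gives 1210 nM, the lowest of the three numbers so far. Compound 1 `c1ccc(-c2ccc(-c3ccc(-c4nc5ccccc5[nH]4)cc3)cc2)cc1` gives 100000 nM, and compound 2 `FC(F)(F)c1ccc(-c2ccc(-c3ccc(-c4nc5ccccc5[nH]4)cc3)cc2)cc1` gives 33900 nM. Compound 4 `CN(C)c1ccc(-c2ccc(-c3ccc(-c4nc5c(O)cccc5[nH]4)cc3)cc2)cc1` turns the phenyl of compound 3 into 4-(dimethylamino)phenyl, with dimethylamino in place of hydrogen on an aromatic carbon.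

Two measured steps can be weighed. The nearer guide is a 2.9-fold lower number from compound 1 to compound 2 (0.47 log units; beyond the scatter), a modest step with trifluoromethyl in place of hydrogen on an aromatic carbon, although that is a different group on a different parent. The other, an 83-fold lower number from compound 1 to compound 3 (1.92 log units; beyond the scatter), is large, but it concerns the hydroxy that compound 4 keeps, so it says little about the new change. Within the data shown here, no measured compound carries dimethylamino, so only a modest step towards a lower number in this assay is expected, and the opposite direction remains possible. The expected change is a 2.4-fold lower number from compound 3 to compound 4 (0.38 log units; beyond the scatter). The estimate for compound 4 is 500 nM, with an expected range of 100 nM to 2500 nM.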

Compound 4, concentration for 50% growth inhibition: 6320 nM
The estimate for compound 4 lay 13-fold (1.10 log units) below the measured number; the measured number lies above the stated range.
By their numbers in this assay, from the lowest: compound 3; then compound 4; then compound 2; then compound 1.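

Measured in this assay the change to 4-(dimethylamino)phenyl brings a 5.2-fold higher number from compound 3 to compound 4 (0.72 log units; beyond the scatter) and so weakens growth inhibition, which shows that this position is not indifferent to what sits on it. Within the data shown here, the only earlier change on that phenyl, trifluoromethyl in place of hydrogen, gave a 2.9-fold lower number from compound 1 to compound 2 (0.47 log units; beyond the scatter) but on the parent without the hydroxy, so changes at this position need not all push the number the same way. Nothing available here explains why dimethylamino raises the number.

Among these compounds, whether trifluoromethyl would also lower the number on compound 3 remains open, as that pair has no measured step. From the compounds shown here alone, it is equally open how a plain amine, a methoxy or a carboxylic acid at this position would compare with dimethylamino.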